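A few compounds are considered here, and "the series" means these few. Any claim that something is new, unique, unknown or untested is made for them only; others in the source may bear on it.

Compound 2 `CCC1(Cc2ccccc2)OS(=O)(=O)C=C1OC` is known in an ADME assay on HEL cells (Homo sapiens) for cytotoxicity, with a stated time of 3 days (a lower number here means that less compound is tolerated, a higher number that more compound is tolerated), only through a limit of the assay, > 200000 nM. Compound 1 `CCC1(Cc2ccccc2)OS(=O)(=O)C=C1OCC(=O)OC` in this assay also reaches only a limit, > 200000 nM. Going by the values given here, the one measured step, a step that the two limits leave unreadable from compound 1 to compound 2, therefore carries no readable size. Compound 3 `CCC1(Cc2ccccc2)OS(=O)(=O)C=C1NCc1ccccc1` differs from compound 2 by benzylamino in place of methoxy on a double-bonded ring carbon. Among the compounds with values here, no measured step bears on this change, and both known values rest at the limit of > 200000 nM in this assay, at which 2 of the 2 values shown sit, so no direction can be drawn. Compound 3 is expected to stay near that limit, at 200000 nM, within 50000 nM to 500000 nM. The estimated step of a number no higher from compound 2 to compound 3 (the limit leaves the size open) is accordingly expected to lie within the scatter.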

Compound 3, half-maximal cytotoxic concentration: 92000 nM
Compound 3: middle estimate off by 2.2-fold (0.34 log units), on the high side, within the range that was stated.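

In this assay, the double-bonded ring carbon now yields a step that can be read: benzylamino in place of methoxy gives an at least 2.1-fold lower number from compound 2 to compound 3 (0.33 log units; beyond the scatter). Benzylamino in place of (methoxycarbonyl)methoxy at the same carbon gives an at least 2.1-fold lower number from compound 1 to compound 3 (0.33 log units; beyond the scatter). Only compound 3 gives a number rather than a limit: the limit of > 200000 nM in this assay, at which 2 of the 3 values shown sit.

The compounds shown leave open whether these steps follow the nitrogen or the aromatic ring of benzylamino, which methylamino or benzyloxy at this carbon would separate. From the compounds shown here alone, the full size of both steps also stays open.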